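The source may report more compounds than this note shows. Statements on the series, on what has been measured and on what is new or still open speak of the compounds shown alone.

Compound 1 `Cc1cc(Nc2cc(-c3ccccc3)[nH]n2)n2nc(SCC(=O)c3ccccc3)nc2n1` gives 33300 nM
Compound 2 `Cc1cc(Nc2cc(-c3ccccc3)[nH]n2)n2nc(SCC3CC3)nc2n1` gives > 50000 nM (a limit)

In an ADME assay on GES1 cells (Homo sapiens) for inhibition, read by MTT assay, with a stated time of 72 h (on this read-out lower numbers stand for stronger inhibition and higher numbers for weaker inhibition), compound 2 gives > 50000 nM, which is a limit and not a number. That is the limit of > 50000 nM in this assay, at which 1 of the 2 values shown sits.

Compound 3 `Cc1cc(Nc2cc(-c3ccccc3)[nH]n2)n2ncnc2n1` differs from compound 2 as follows: hydrogen in place of (cyclopropylmethyl)sulfanyl on an aromatic carbon. It carries hydrogen in place of (cyclopropylmethyl)sulfanyl on an aromatic carbon.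

Among the compounds with values here, the only measured step bearing on this is an at least 1.5-fold higher number from compound 1 to compound 2 (0.17 log units; that floor lies within the scatter). It swaps benzoyl for cyclopropyl and keeps the sulfur, so it is weak guidance, and no step beyond the scatter is expected in this assay.

The step expected is a number no higher from compound 2 to compound 3 (the limit leaves the size open).

Compound 3 is estimated at 50000 nM, with an expected range of 20000 nM to 120000 nM.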

Compound 3, half-maximal inhibitory concentration: > 50000 nM
Compound 3: no number, only a limit; the forecaster's own chance of this, stated with the estimate: 55%; the middle value sits exactly at the limit.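

Compound 3 shows that this aromatic carbon can carry plain hydrogen, with no sulfur at all, and still give only a limit in this assay, as compound 2 does, so the step between those two cannot be read. Set against the benzoyl-bearing compound, hydrogen in place of (benzoylmethyl)sulfanyl gives an at least 1.5-fold higher number from compound 1 to compound 3 (0.17 log units; that floor lies within the scatter). The limit now recurs across the series: the limit of > 50000 nM in this assay, at which 2 of the 3 values shown sit.

From the compounds shown here alone, whether an amine or a carboxylic acid on this carbon would give a readable number stays open. So does whether a longer chain on the sulfur would.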